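Trifluoromethyl in place of fluoro, a second instance

The compounds below may be only part of what the source reports. "The series", "measured", "known", "first", "only" and "open" are said of these compounds alone.

Compound 1 `CCOC(=O)C1=C(Nc2ccc(F)cc2)S/C(=C\c2ccc[nH]2)C1=O` and compound 2 `CCOC(=O)C1=C(Nc2cccc(F)c2)S/C(=C\c2ccc[nH]2)C1=O` share a core; their difference is 3-fluorophenyl in place of 4-fluorophenyl on an amine nitrogen. Compound 3 `CCOC(=O)C1=C(Nc2ccc(C(F)(F)F)cc2)S/C(=C\c2ccc[nH]2)C1=O` differs from compound 1 by trifluoromethyl in place of fluoro on an aromatic carbon. In a functional assay on A549 cells (Homo sapiens) for inhibition, read by MTT assay, with a stated time of 72 h, tested at 10 uM (a higher number here means more inhibition at the concentration tested (going by the name of the read-out), a lower number less inhibition), compound 1 gives < 10%, a limit. Compound 2 gives < 10%, also a limit. Compound 3 gives 30.1%. The step that the two limits leave unreadable from compound 1 to compound 2 cannot be read because of the limit of < 10% in this assay, at which 2 of the 3 values shown sit. The step of a number at least 20.1 percentage points higher from compound 1 to compound 3 (beyond the scatter) is beyond the scatter. Compound 4 `CCOC(=O)C1=C(Nc2cccc(C(F)(F)F)c2)S/C(=C\c2ccc[nH]2)C1=O` is not yet measured; it differs from compound 2 by trifluoromethyl in place of fluoro on an aromatic carbon. The place differs in one word, meta to a large group rather than para to a large group, so this is the same kind of change, not the same. The expected step is a number at least 15 percentage points higher from compound 2 to compound 4 (beyond the scatter), resting on the step seen in a number at least 20.1 percentage points higher from compound 1 to compound 3 (beyond the scatter). Compound 4 is estimated at 25%, between 5% and 45%.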

Compound 4, a percentage reported as inhibition, at one concentration (the size of the read-out at that concentration, not a potency): 22.8%
Compound 4: middle estimate off by 2.2 percentage points, on the high side; measured number inside the range.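

In this assay, trifluoromethyl in place of fluoro goes the same way on the second core, with a number at least 12.8 percentage points higher from compound 2 to compound 4 (beyond the scatter). The direction therefore carries over between the two cores shown, but no difference in the size of the change can be claimed: the same change on two cores in this assay, a number at least 20.1 percentage points higher (beyond the scatter) from compound 1 to compound 3 and a number at least 12.8 percentage points higher (beyond the scatter) from compound 2 to compound 4; the limit leaves it open whether they differ. The full size of each step cannot be read, nor can the step between compound 1 and compound 2, and both fluoro compounds stand at a limit: the limit of < 10% in this assay, at which 2 of the 4 values shown sit.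

The compounds shown leave open whether a chlorine, a nitrile or a methoxy group in place of trifluoromethyl would give a similar result, and whether the change carries over when the ethyl ester becomes a carboxylic acid or an amide. Only a single concentration on one cell line stands here, and no potency follows from it.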